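A few compounds are considered here, and "the series" means these few. Any claim that something is new, unique, unknown or untested is made for them only; others in the source may bear on it.

In a functional assay on HL-60 cells (Homo sapiens) for antiproliferative activity, read by MTT assay, with a stated time of 72 h (a lower number here means a stronger inhibitor, a higher number a weaker inhibitor), compound 1 (`NC1=NC2(CCOCC2)N(OCCCOc2ccccc2)C(N)=N1`) gives 2460 nM and stands highest of the two measured compounds. Among the compounds with values here, compound 2 (`NC1=NC2(CCSCC2)N(OCCCOc2cc(Cl)c(Cl)cc2Cl)C(N)=N1`) gives 730 nM and stands lower, with no single-change step linking the two. Compound 3 (`NC1=NC2(CCOCC2)N(OCCCOc2ccc(Cl)cc2Cl)C(N)=N1`) keeps the core of compound 1 and carries 2,4-dichlorophenyl in place of phenyl on an oxygen on a saturated carbon. Within the data shown here, with chlorines on its phenyl ring, compound 2 at 730 nM is the sole guide, so a lower number is expected in this assay. The expected change is a moderate one (a 2.5-fold lower number from compound 1 to compound 3 (0.39 log units; beyond the scatter)). Compound 3 is estimated at 1000 nM with a range from 350 nM to 2400 nM expected.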

Compound 3, half-maximal inhibitory concentration: 330 nM
Compound 3: middle estimate off by 3.0-fold (0.48 log units), on the high side, and the stated range ends above it.
By their numbers in this assay, from the lowest: compound 3; then compound 2; then compound 1.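

In this assay the exchange of phenyl for 2,4-dichlorophenyl on an oxygen on a saturated carbon gives a 7.5-fold lower number from compound 1 to compound 3 (0.87 log units; beyond the scatter) with the core of compound 1 unchanged. Within the data shown here, this is the first reading of this position alone, since compound 2 differs from compound 1 in more than one place. Nothing measured here bears on why the step occurs. Still open, going by these compounds, is whether a single chlorine on the phenyl ring would give a comparable step, and how methoxy or trifluoromethyl would read in place of the chlorines.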